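Chain terminus swap in an aminopyrimidinone series

This account rests on a few compounds, and the source may have more. Where it says the series, first, only, none or still open, it means among the compounds named here.

Compound 1 `CC1(C)C(=O)Nc2nc(-n3nc(CCCC(F)(F)F)c4cc(Cl)ccc43)nc(N)c21` gives 117000 nM in an assay on CHO cells for activation of soluble guanylate cyclase alpha1/beta1 complex (Homo sapiens), read by cGMP accumulation; a higher number here means that more compound is needed for the effect, a lower number that less compound is needed.
Compound 2 `COC(=O)N(C)c1c(N)nc(-n2nc(Cc3c(F)ccc(F)c3F)c3cc(Cl)ccc32)nc1N` gives 700 nM in this assay.
Compound 3 `CC1(C)C(=O)Nc2nc(-n3nc(CCC(F)(F)F)c4ccccc43)nc(N)c21` gives 882000 nM in this assay.

Compound 1 stands second highest of the three numbers. Its nearest neighbour in value is compound 3, whose number is higher by an amount beyond the scatter; the furthest is compound 2, whose number is lower by a margin well beyond the scatter. Compound 2 also carries a different substitution on the core, so its two values with compound 1 show only that the two sit far apart.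

Compound 4 `CCCCCc1nn(-c2nc(N)c3c(n2)NC(=O)C3(C)C)c2ccc(Cl)cc12` has not been measured. It differs from compound 1 by ethyl in place of trifluoromethyl on a saturated chain carbon, three bonds along the chain from an aromatic carbon; the chlorine on the fused ring and the rest of the core stay the same. Among the measured compounds shown here, no measured pair in this set isolates that change, so the size of the step is open. On what the set shows, no step beyond the scatter is expected in this assay, and the estimate keeps compound 4 close to compound 1, with the step from compound 1 to compound 4 expected at a 1.1-fold lower number from compound 1 to compound 4 (0.03 log units; within the scatter). Compound 4 is expected to give about 110000 nM, with a range from 30000 nM to 400000 nM.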

Compound 4, half-maximal effective concentration: 90000 nM
For compound 4 the middle estimate is 1.2-fold (0.09 log units) above the measured one; the measured number falls inside the stated range.
By their numbers in this assay, from the lowest: compound 2; then compounds 4 and 1 (each within the scatter of the next); then compound 3.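

Among the compounds shown here, exchanging 4,4,4-trifluorobutyl for pentyl gives a 1.3-fold lower number from compound 1 to compound 4 (0.11 log units; within the scatter) in this assay, and this is the only pair in the set that differs in one place. At this position, on the shared core carrying the chlorine on the fused ring, the chain end can therefore be trifluoromethyl or ethyl with no step beyond the scatter, so the fluorine atoms of the chain end are not needed to keep the number at this level. Nothing available accounts for the two chains reading alike, and this single pair gives no basis for extending the finding to other cores.

On these data alone, whether the same tolerance holds for an amine, a carboxylic acid or a hydroxyl group at the chain end, or for a longer chain such as hexyl, remains open. Compound 3, at 882000 nM, differs from compound 1 in both chain length and the chlorine on the fused ring, so the contributions of those two changes cannot be separated, and the steps to compound 2 and compound 3 cannot be read.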